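The source may hold more compounds than are shown below. What is called first, only, known or untested is meant among the compounds shown, and "the series" means these compounds.

Measured compounds:
Compound 1 `N#CC1=C(N)Oc2c(c3nc4ccccc4nc3c3ccccc23)C12C(=O)N(Cc1cnnn1-c1ccccc1Cl)c1ccccc12`: in an ADME assay on L02 cells (Homo sapiens) for antiproliferative activity, read by MTT assay, with a stated time of 48 h (a higher number here means a weaker inhibitor, a lower number a stronger inhibitor), compound 1 gives > 50000 nM, which is a limit of the assay and not a number.
Compound 2 `N#CC1=C(N)Oc2c(c3nc4ccccc4nc3c3ccccc23)C12C(=O)N(Cc1cnnn1-c1ccccc1Br)c1ccccc12`: in this assay compound 2 gives > 50000 nM, likewise a limit.
Compound 3 `N#CC1=C(N)Oc2c(N)cc3nc4ccccc4nc3c2C12C(=O)N(Cc1cnnn1-c1ccc(F)cc1)c1ccccc12`: in this assay compound 3 gives > 50000 nM, again a limit.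

Compound 3 thus stands at the limit of this assay, and nothing places it relative to the other two compounds, whose values are limits as well; all three sit together, as summarised by the limit of > 50000 nM in this assay, at which 3 of the 3 values shown sit. Going by the values given here, the only step between measured compounds that differ in one place is a step that the two limits leave unreadable from compound 1 to compound 2, and since both of its ends are limits, its size cannot be read.

Compound 4 `COc1ccc(OC)c(-n2nncc2CN2C(=O)C3(C(C#N)=C(N)Oc4c(N)cc5nc6ccccc6nc5c43)c3ccccc32)c1` differs from compound 3 in one place: 2,5-dimethoxyphenyl in place of 4-fluorophenyl on an aromatic nitrogen. Among the compounds with values here, no measured step bears on this change; the single step available is unreadable and concerns a different change. The series therefore offers no ground to expect compound 4 to depart from where compound 3 stands, and the expected step that the limit leaves unreadable from compound 3 to compound 4 is none beyond the scatter. Compound 4 is estimated at 60000 nM, with a range from 30000 nM to 150000 nM, and is most likely to be reported as a limit once more.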

Compound 4, half-maximal inhibitory concentration: > 50000 nM
Compound 4 was reported as a limit; the forecaster's own chance of this, stated with the estimate: 85%; the middle value lies beyond the limit too.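

Compound 3 and compound 4 both give limits in this assay, so no step between them can be read, and the series stays at one limit: the limit of > 50000 nM in this assay, at which 4 of the 4 values shown sit.

The compounds shown leave open where the true values lie and whether 2,5-dimethoxyphenyl in place of 4-fluorophenyl changes the read-out at all.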